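The compounds below may be only part of what the source reports. "The series", "measured", "known", "first", "only" and "open" are said of these compounds alone.

Within the data shown here, the series so far holds two compounds on a shared core. In a functional assay on A549 cells (Homo sapiens) for inhibition, read by sulforhodamine B assay, with a stated time of 72 h (on this read-out higher numbers stand for weaker inhibition of growth and lower numbers for stronger inhibition of growth), compound 1 `CCOC(=O)/C=C/c1ccncc1-c1ccc2ccccc2c1` gives 5380 nM. Compound 2 `NC(=O)/C=C/c1ccncc1-c1ccc2ccccc2c1` gives > 10000 nM, and this is a limit of this assay, not a number. Compound 2 therefore has no exact place on the scale, and the record for the pair reads (the limit of > 10000 nM in this assay, at which 1 of the 2 values shown sits).

The next change leads to compound 3 `CN(C)C(=O)/C=C/c1ccncc1-c1ccc2ccccc2c1`: dimethylamino in place of amino on a carbonyl carbon. Among the measured compounds shown here, only one measured step touches this carbonyl carbon, with amino in place of ethoxy: an at least 1.8-fold higher number from compound 1 to compound 2 (0.26 log units; that floor lies within the scatter). The floor of that step lies within the scatter, and it is a different exchange, so it sets no size or direction for the new one. No step beyond the scatter is expected in this assay, and a reading near the top of the measurable range seems likely, with a real chance of another limit. The expected step is an at least 1.1-fold lower number from compound 2 to compound 3 (0.04 log units; that floor lies within the scatter). For compound 3 the estimated value is 9000 nM, within an expected range of 4000 nM to 16000 nM.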

Compound 3, concentration for 50% growth inhibition: 5800 nM
Beside the measured number, compound 3's estimate is 1.6-fold (0.19 log units) above it, within the range that was stated.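

In this assay, placing dimethylamino on this carbonyl carbon gives a reading inside the measurable range, and the step from the amino amide is an at least 1.7-fold lower number from compound 2 to compound 3 (0.23 log units; that floor lies within the scatter). Against the ethoxy ester the reading is a 1.1-fold higher number from compound 1 to compound 3 (0.03 log units; within the scatter), so on this evidence the ester and the dimethylamino amide cannot be told apart, and exchanging ethoxy for dimethylamino at this place leaves the growth inhibition reading without a detectable change. Compound 2 remains a limit of the assay and not a number, so the floor of its step cannot establish a real difference from the dimethylamino amide: the limit of > 10000 nM in this assay, at which 1 of the 3 values shown sits.

Still open, as far as these compounds go, is whether a cyclic amine such as morpholine or pyrrolidine on this carbonyl carbon, or a free carboxylic acid in place of the ester, would move the reading beyond the scatter from compound 1. Also open, from the compounds shown here alone, is whether methylamino, or a longer chain on the amide nitrogen such as diethylamino, would stay in the measurable range or fall to the limit seen for the amino amide.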